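A few compounds are considered here, and "the series" means these few. Any claim that something is new, unique, unknown or untested is made for them only; others in the source may bear on it.

Compound 1 `CCCCNC(=O)N1CC1C#N` — > 12000 nM
Compound 2 `N#CC1CN1C(=O)Nc1ccc(F)cc1` — 2700 nM
Compound 3 `CC(=O)c1cccc(NC(=O)N2CC2C#N)c1` — 3500 nM

In a functional assay on MCF7 cells (Homo sapiens) for inhibition (on this read-out lower numbers stand for stronger inhibition and higher numbers for weaker inhibition), compound 1 gives no number but only a limit, > 12000 nM. Compound 1 thus stands at the limit of > 12000 nM in this assay, at which 1 of the 3 values shown sits. The two aryl ureas fare differently: compound 2 gives 2700 nM and compound 3 gives 3500 nM, and these two values lie within the scatter of each other.

Compound 4 `CNC(=O)N1CC1C#N` has not been measured. It differs from compound 1 by hydrogen in place of propyl on a saturated chain carbon bound to an amide-type nitrogen, so the chain on the urea nitrogen is shortened further. Among the measured compounds shown here, nothing among the measured compounds tracks a change of this kind, so the step is expected to be a step that the limit leaves unreadable from compound 1 to compound 4, nothing beyond the scatter. Compound 4 is therefore estimated at 20000 nM, with a range from 8000 nM to 60000 nM, most probably again reported only as a limit.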

Compound 4, half-maximal inhibitory concentration: 18000 nM
For compound 4 the middle estimate is 1.1-fold (0.05 log units) above the measured one; low and high end bracket the measured number.
By their numbers in this assay, from the lowest: compounds 2 and 3 (each within the scatter of the next); then compound 4.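

Among the compounds shown here, compound 1 carries only a limit, so no step from it to compound 4 can be read because of that limit: the limit of > 12000 nM in this assay, at which 1 of the 4 values shown sits. The compounds shown leave open whether, in this assay, going from butyl to methyl changes inhibition at all.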